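The source may hold more compounds than are shown below. What is called first, only, known or untested is meant among the compounds shown, and "the series" means these compounds.

Compound 1 `CCN(C)C(=O)N1CCN(C(=S)SCc2cn(Cc3ccccc3F)nn2)CC1` was tested in a functional assay on SMMC-7721 cells (Homo sapiens) for cytotoxicity, read by MTT assay, with a stated time of 72 h (a lower number here means a stronger inhibitor, a higher number a weaker inhibitor), where compound 1 gives 19700 nM. Compound 2 `CC(C)(C)NC(=O)N1CCN(C(=S)SCc2cn(Cc3ccccc3F)nn2)CC1` differs from it only at the carbonyl carbon, where (tert-butyl)amino replaces ethyl(methyl)amino. For compound 2 this assay reports only a limit, > 128000 nM, and not a number. The change is therefore read as an at least 6.4-fold higher number from compound 1 to compound 2 (0.81 log units; beyond the scatter), with the size resting on (the limit of > 128000 nM in this assay, at which 1 of the 2 values shown sits). Among the values shown, compound 1 thus holds the only true number, the other being a limit.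

Compound 3 `CCN(C)C(=O)N1CCN(C(=S)SCc2cn(Cc3ccc(F)cc3)nn2)CC1` keeps the ethyl(methyl)amino group of compound 1 and alters a different part: 4-fluorophenyl in place of 2-fluorophenyl on a saturated chain carbon bound to an aromatic nitrogen. For the measured compounds named here, no measured step touches this place; the one measured step, from compound 1 to compound 2, concerns the carbonyl end and says nothing about moving the fluorine around the ring. With nothing to point in either direction, the expectation for compound 3 in this assay is a step of no change at the digits printed from compound 1 to compound 3 (within the scatter), that is, no change beyond the scatter. The estimated value for compound 3 is 19700 nM, with a range from 7000 nM to 55000 nM.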

Compound 3, half-maximal inhibitory concentration: 23700 nM
For compound 3 the middle estimate is 1.2-fold (0.08 log units) below the measured one; the range from low to high includes it.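

For the compounds shown here, this result gives the first reading at the fluorobenzyl end of the molecule, a part the earlier step did not touch. In this assay, 4-fluorophenyl in place of 2-fluorophenyl gives a 1.2-fold higher number from compound 1 to compound 3 (0.08 log units; within the scatter), so the two fluorine placements cannot be told apart here, whereas the change at the carbonyl end gave an at least 6.4-fold higher number from compound 1 to compound 2 (0.81 log units; beyond the scatter). Among the compounds shown, then, this swap on the saturated chain carbon bound to an aromatic nitrogen is tolerated in this cell assay, while the one change at the carbonyl carbon is not, and nothing measured here offers an explanation for either outcome.

Going by these compounds, the finding covers only two fluorine placements on one ring, so it remains open whether a plain phenyl, 3-fluorophenyl, 4-chlorophenyl or 4-methoxyphenyl group would also read like compound 1, or whether a group of another kind, such as a pyridine ring or a longer chain between the ring and the aromatic nitrogen, would shift the number beyond the scatter. On these data alone, it is also open whether the same tolerance would hold with a carbonyl end other than the ethyl(methyl)amino group of compound 1.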